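Methyl to fluoro in an antiproliferative pair

A few compounds are considered here, and "the series" means these few. Any claim that something is new, unique, unknown or untested is made for them only; others in the source may bear on it.

Compound 1 `COc1cc(-n2cnc3ccc(-c4ccc([N+](=O)[O-])cc4)cc32)cc(OC)c1OC`: 740 nM
Compound 2 `COc1cc(-n2cnc3ccc(-c4cccc(C)c4)cc32)cc(OC)c1OC`: 360 nM

Going by the values given here, in a functional assay on MCF7 cells (Homo sapiens) for antiproliferative activity, read by MTT assay, with a stated time of 72 h (on this read-out higher numbers stand for weaker inhibition and lower numbers for stronger inhibition), compound 2 gives 360 nM, the lower of the two numbers measured so far. Compound 3 `COc1cc(-n2cnc3ccc(-c4cccc(F)c4)cc32)cc(OC)c1OC` is the next to be read. It carries fluoro in place of methyl on an aromatic carbon, meta to a large group: fluoro in place of methyl on an aromatic carbon. Among the compounds with values here, only one measured step bears on this change, a 2.1-fold lower number from compound 1 to compound 2 (0.31 log units; beyond the scatter). That step, with 3-methylphenyl in place of 4-nitrophenyl, was modest, and it involves a different pair of groups. Within the data shown here, no measured compound yet shows what fluoro does here. A small change, none beyond the scatter, is therefore expected, and the estimated step is a 1.1-fold higher number from compound 2 to compound 3 (0.05 log units; within the scatter). Compound 3 is expected at 400 nM, with an estimated range of 180 nM to 900 nM.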

Compound 3, half-maximal inhibitory concentration: 2350 nM
The estimate for compound 3 lay 5.9-fold (0.77 log units) below the measured number, outside the stated range (above it).
By their numbers in this assay, from the lowest: compound 2; then compound 1; then compound 3.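

In this assay, this position proves sensitive to the exchange of a single heavy atom: with 3-fluorophenyl in place of 3-methylphenyl, the read-out gives a 6.5-fold higher number from compound 2 to compound 3 (0.81 log units; beyond the scatter), a clear loss that the earlier pair could not reveal. The fluoro compound also falls behind the 4-nitrophenyl compound, with a 3.2-fold higher number from compound 1 to compound 3 (0.50 log units; beyond the scatter), so the order of the three groups is now 3-methylphenyl, then 4-nitrophenyl, then 3-fluorophenyl, and a group's small size alone does not keep activity here. Nothing at hand tells why methyl and fluoro part so widely.

The compounds shown leave open whether methyl is unusually favourable on this carbon or fluoro unusually poor. Chloro, methoxy or an amine in the same place, or a plain phenyl, could settle which of the two readings holds.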